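This account rests on a few compounds, and the source may have more. Where it says the series, first, only, none or still open, it means among the compounds named here.

Measured in an ADME assay on KB cells (Homo sapiens) for cytotoxicity, with a stated time of 48 h; a lower number here means a stronger inhibitor, a higher number a weaker inhibitor:

- Compound 1 `CC1=CCC[C@](C)(CC/C(C)=C/CC2=C(O)C(=O)C=C(N[C@H](C(=O)O)[C@@H](C)O)C2=O)[C@@H]1C`: > 10 ug/mL, a limit
- Compound 2 `CC1=CCC[C@](C)(CC/C(C)=C/CC2=C(O)C(=O)C=C(N[C@@H](C(=O)O)[C@@H](C)O)C2=O)[C@@H]1C`: > 10 ug/mL, a limit
- Compound 3 `CC1=CCC[C@](C)(CC/C(C)=C/CC2=C(O)C(=O)C=C(N[C@@H](C(=O)O)C(C)C)C2=O)[C@@H]1C`: > 10 ug/mL, a limit

Compound 3 has no number of its own, only the limit > 10 ug/mL. The three compounds together show (the limit of > 10 ug/mL in this assay, at which 3 of the 3 values shown sit).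

Compound 4 `COC1=CC(=O)C(O)=C(C/C=C(\C)CC[C@@]2(C)CCC=C(C)[C@H]2C)C1=O` differs from compound 3 by a single exchange, methoxy in place of (1-carboxy-2-methylpropyl)amino on a double-bonded ring carbon.

Three measured steps lie nearest to this change: a step that the two limits leave unreadable from compound 1 to compound 2, a step that the two limits leave unreadable from compound 1 to compound 3 and a step that the two limits leave unreadable from compound 2 to compound 3. None has a readable size, and all of them alter the amino substituent while keeping it in place, whereas compound 4 loses that substituent altogether. They therefore give no measure for the exchange.

The expectation starts from the limit for compound 3, > 10 ug/mL. Only a modest move towards stronger inhibition in this assay is expected, and compound 4 may equally well end up reported as a limit.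

The expected step is an at least 1.4-fold lower number from compound 3 to compound 4 (0.15 log units; that floor lies within the scatter).

For compound 4 the estimated value is 7 ug/mL, with an expected range from 2.5 ug/mL to 20 ug/mL.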

Compound 4, half-maximal inhibitory concentration: > 10 ug/mL
Compound 4 ended at the assay's limit; the forecaster's own chance of this, stated with the estimate: 40%; middle value at least 1.4-fold (0.15 log units) from the limit.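

For the compounds shown here, compound 4 gives > 10 ug/mL, which is a limit, so no step from compound 1, compound 2 or compound 3 to compound 4 can be read. The compounds shown leave open how far any of them lies past that limit, and so whether exchanging the amino substituent for methoxy changes the result in this assay at all.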